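The source may hold more compounds than are shown below. What is called first, only, known or untested is meant among the compounds shown, and "the series" means these compounds.

Compound 1 `CCCCCn1c(-c2ccccc2)nc2c(N)ccnc21` and compound 2 `CCCCCn1c(-c2ccc(OC)cc2)nc2c(N)ccnc21` share one core. In an assay on isolated protein for inhibition of high affinity 3',5'-cyclic-AMP phosphodiesterase 7A (Homo sapiens), read by cAMP accumulation, with a stated time of 20 min (on this read-out lower numbers stand for stronger inhibition and higher numbers for weaker inhibition), compound 1 gives only a limit, > 200000 nM. In this assay compound 2 likewise gives only a limit, > 200000 nM. The step that the two limits leave unreadable from compound 1 to compound 2 cannot be read, since both values sit at the limit of > 200000 nM in this assay, at which 2 of the 2 values shown sit. Compound 3 `CCCCCn1c(-c2ccc([N+](=O)[O-])cc2)nc2c(N)ccnc21` differs from compound 2 by nitro in place of methoxy on an aromatic carbon. No measured step bears readably on this change, so no direction can be drawn from the numbers shown. Compound 3 is expected to give an estimated 300000 nM, in a range from 100000 nM to 1000000 nM, most likely again reported only as a limit. The expected step that the limit leaves unreadable from compound 2 to compound 3 is estimated to lie within the scatter.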

Compound 3, half-maximal inhibitory concentration: > 200000 nM
Compound 3 ended at the assay's limit (the forecaster's own chance of this, stated with the estimate: 85%); the middle value is on the limit's open side.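

For the compounds shown here, no step among compound 1, compound 2 and compound 3 can be read in this assay: the limit of > 200000 nM in this assay, at which 3 of the 3 values shown sit. The compounds shown leave open whether any change on the shared core would give a measurable value rather than a limit.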